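The source may report more compounds than this note shows. Statements on the series, on what has been measured and on what is new or still open speak of the compounds shown alone.

Measured compounds:
Compound 1 `COc1ccc(-c2cc(C(=O)Nc3nc4ccc(F)cc4s3)nc3cc(-c4ccccc4)nn23)cc1` gives 41700 nM in a functional assay on HeLa cells (Homo sapiens) for cytotoxicity, read by MTT assay, with a stated time of 48 h; on this read-out lower numbers stand for stronger inhibition and higher numbers for weaker inhibition.
Compound 2 `Cc1cc2nc(NC(=O)c3cc(-c4ccc(F)cc4)n4nc(-c5ccccc5)cc4n3)sc2cc1C` gives 18200 nM in this assay.

Of the two numbers, compound 2 stands at the lower one, which on this read-out means the stronger inhibition of the two; the gap to compound 1 lies beyond the usual scatter of repeated measurements. Within the data shown here, the shared core of the two compounds differs in its outer groups, and no single-change step between them is available.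

Compound 3 `COc1ccc(-c2cc(C(=O)Nc3nc4cc(C)c(C)cc4s3)nc3cc(-c4ccccc4)nn23)cc1` has not yet been tested in this assay. It is built from compound 2 by one change: methoxy in place of fluoro on an aromatic carbon. Among the measured compounds shown here, since no measured pair shows this same change on its own, there is no direct guide to its size. A small step is expected for a 1.4-fold higher number from compound 2 to compound 3 (0.14 log units; within the scatter), leaning toward a slightly higher number, though a result within the scatter would not surprise. Compound 3 is estimated at 25000 nM in this assay, with a range from 9000 nM to 70000 nM.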

Compound 3, half-maximal inhibitory concentration: 14100 nM
Compound 3: middle estimate off by 1.8-fold (0.25 log units), on the high side; low and high end bracket the measured number.
By their numbers in this assay, from the lowest: compounds 3 and 2 (each within the scatter of the next); then compound 1.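

In this assay the change from 4-fluorophenyl to 4-methoxyphenyl gives a 1.3-fold lower number from compound 2 to compound 3 (0.11 log units; within the scatter) with the 5,6-dimethyl-1,3-benzothiazol-2-yl group held in place, so this first direct comparison at this position finds no measurable difference between fluoro and methoxy. Among these compounds, the other single change, 5,6-dimethyl-1,3-benzothiazol-2-yl in place of 6-fluoro-1,3-benzothiazol-2-yl on the amide-type nitrogen with 4-methoxyphenyl held in place, gives a 3.0-fold lower number from compound 1 to compound 3 (0.47 log units; beyond the scatter) and is a modest step, so only this change separates its two compounds beyond the scatter.

Still open, going by these compounds, is whether an amine, a carboxylic acid or a longer chain in place of methoxy would move the number beyond the scatter, and whether fluoro and methoxy would also match alongside 6-fluoro-1,3-benzothiazol-2-yl. Nothing at hand gives a reason for either step.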